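The source may hold more compounds than are shown below. What is called first, only, known or untested is meant among the compounds shown, and "the series" means these compounds.

Measured compounds:
- compound 1, `COc1ccc(-c2ccnc(Nc3ccc4c(c3)c(/C=C3/C(=O)Nc5ccccc53)cn4C)n2)cc1`: "not determined" (no result reported)
- compound 2, `Cn1cc(/C=C2/C(=O)Nc3ccccc32)c2cc(Nc3nccc(-c4ccc(O)cc4)n3)ccc21`: 58400 nM

Compound 1 carries a methoxy group where compound 2 carries a hydroxy group; for compound 1 the entry in an ADME assay on RWPE-1 cells (Homo sapiens) for cytotoxicity, read by MTT assay, with a stated time of 48 h (on this read-out lower numbers stand for stronger inhibition and higher numbers for weaker inhibition), reads "not determined" (no result reported), so no number is available. Within the data shown here, compound 2 is therefore the only compound with a number in this assay, and it stands alone there: in this assay compound 2 gives 58400 nM, a high number that means only weak inhibition of these cells.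

Compound 3, `Cn1cc(/C=C2/C(=O)Nc3ccccc32)c2cc(Nc3nccc(-c4ccc(Cl)cc4)n3)ccc21`, differs from compound 2 in one place: chloro in place of hydroxy on an aromatic carbon. Among the measured compounds shown here, nothing among the measured compounds shows how such a swap plays out here, since no pair of measured compounds differs in this way.

With only compound 2 as a reference, the expectation rests on that single value. A small move toward stronger inhibition is expected, but one that may not rise above the usual scatter, so the step from compound 2 to compound 3 is estimated at a 1.9-fold lower number from compound 2 to compound 3 (0.29 log units; within the scatter). Compound 3 is accordingly expected to give about 30000 nM in this assay, with a likely range from 8000 nM to 100000 nM.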

Compound 3, half-maximal inhibitory concentration: 41100 nM
For compound 3 the middle estimate is 1.4-fold (0.14 log units) below the measured one; low and high end bracket the measured number.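

In this assay, replacing 4-hydroxyphenyl with 4-chlorophenyl gives a 1.4-fold lower number from compound 2 to compound 3 (0.15 log units; within the scatter) and so leaves compound 2 and compound 3 indistinguishable on this read-out. Among these compounds, this is the first pair with numbers at this position, and it shows that a chloro group, with 0 hydrogen-bond donors and 0 hydrogen-bond acceptors, can take the place of a hydroxy group, with 1 of each, without a change that rises above the usual scatter. No measured information here explains why the two compounds read alike.

On these data alone, with numbers for only hydroxy and chloro at this position, the result cannot show whether the position generally tolerates change, and it remains open whether an amine, a carboxylic acid or a longer chain such as propoxy would move the number beyond the scatter. The closest comparison also stays out of reach, since in this assay the methoxy-bearing compound 1 has the entry "not determined" (no result reported) and its step to compound 2 or compound 3 cannot be read.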